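Methyl-to-ethyl extension on the aryl tail of compound 1

This account rests on a few compounds, and the source may have more. Where it says the series, first, only, none or still open, it means among the compounds named here.

Compound 1 `C=C(Br)C(=O)Nc1cccc(-c2cn3nc(-c4ccc(C)cc4)sc3n2)c1` carries the bromoacryloyl amide on one aryl ring and the 4-methylphenyl on the other. In a functional assay on L1210 cells (Mus musculus) for inhibition, read by cell counting, with a stated time of 2 days (on this read-out higher numbers stand for weaker inhibition and lower numbers for stronger inhibition), compound 1 gives 920 nM, the lowest of the two numbers recorded. Compound 3 `Cc1ccc(-c2nn3cc(-c4cccc(N)c4)nc3s2)cc1` lacks the acyl group; in this assay compound 3 gives 4800 nM, and the step of a 5.2-fold higher number from compound 1 to compound 3 (0.72 log units; beyond the scatter). Compound 2 `COc1ccc(-c2nn3cc(-c4cccc(N)c4)nc3s2)cc1` bears methoxy where compound 3 bears methyl. In this assay compound 2 gives only a limit, >= 250000 nM, and (the limit of >= 250000 nM in this assay, at which 1 of the 3 values shown sits). The step of an at least 52-fold lower number from compound 2 to compound 3 (1.71 log units; beyond the scatter), so the substituent on the 4-methylphenyl ring matters a great deal.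

Compound 4 `C=C(Br)C(=O)Nc1cccc(-c2cn3nc(-c4ccc(CC)cc4)sc3n2)c1` differs from compound 1 as follows: methyl in place of hydrogen on a saturated chain carbon bound to an aromatic carbon. Going by the values given here, no measured pair shows this exact change; the nearest, from compound 2 to compound 3, swaps methoxy for methyl at the same position and is large, while the acyl step from compound 1 to compound 3 is modest. Methyl to ethyl is a smaller alteration than either, so no step beyond the scatter is expected, with a slight weakening left open.

Compound 4 is estimated at 1100 nM in this assay, between 350 nM and 3500 nM, a step of a 1.2-fold higher number from compound 1 to compound 4 (0.08 log units; within the scatter).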

Compound 4, half-maximal inhibitory concentration: 2200 nM
Compound 4: the middle estimate sits 2.0-fold (0.30 log units) below what was measured, within the range that was stated.
By their numbers in this assay, from the lowest: compound 1; then compound 4; then compound 3. At a limit, above all of these: compound 2.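

In this assay, lengthening the tail from 4-methylphenyl to 4-ethylphenyl gives a modest weakening that can be read (a 2.4-fold higher number from compound 1 to compound 4 (0.38 log units; beyond the scatter)), so a single added methyl on the saturated chain carbon bound to an aromatic carbon is enough to shift the number beyond the scatter. The earlier compounds shown here probed this ring substituent only as methoxy against methyl, and only with hydrogen on the nitrogen, whereas this pair tests it with the bromoacryloyl amide in place and shows that the methyl of compound 1 is not freely extended. Going by these compounds alone, the only evidence available concerns a limit reached by a different compound and gives no reason for the size or direction of this step.

Still open, on these data alone, is whether a longer chain such as propyl, or a branched one such as isopropyl, would continue the weakening seen with ethyl or level off at this position. Equally open, as far as these compounds go, is whether the ethyl group would have a similar effect with hydrogen in place of the bromoacryloyl group, or with a hydroxyl or an amine at the end of the chain.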